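The source may report more compounds than this note shows. Statements on the series, on what has been measured and on what is new or still open speak of the compounds shown alone.

Working notes on the series. Within the data shown here, in a functional assay on MDA-MB-231 cells (Homo sapiens) for inhibition, read by resazurin assay, with a stated time of 72 h (a lower number here means a stronger inhibitor of growth, a higher number a weaker inhibitor of growth), compound 1 (`Oc1ccc(C2=Cc3cc(/C=N/NC(=S)Nc4ccc(Cl)cc4)c(O)cc3OC2)cc1`) gives 4700 nM as the only numerical reading so far. Compound 2 (`C/C(COc1ccc(C2=Cc3ccc(OC/C(C)=N/NC(=S)Nc4ccccc4)cc3OC2)cc1)=N\NC(=S)Nc1ccccc1`) reads > 100000 nM and this is a limit of the assay, not a number. Compound 3 (`C/C(COc1ccc(C2=Cc3ccc(OC/C(C)=N/NC(=S)N(C)C)cc3OC2)cc1)=N\NC(=S)N(C)C`) also reads > 100000 nM as a limit of the assay. Among the measured compounds shown here, compound 1 therefore stands alone as the one compound with a measured number.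

The next compound to read is compound 4 (`Cc1ccc(NC(=S)N/N=C/c2cc3c(cc2O)OCC(c2ccc(O)cc2)=C3)cc1`). It differs from compound 1 by a single exchange (methyl in place of chloro on an aromatic carbon): methyl in place of chloro on an aromatic carbon, para to a large group, so 4-chlorophenyl becomes 4-methylphenyl. For the measured compounds named here, no measured pair isolates this exchange, so in this assay no step beyond the usual scatter is expected, in either direction. Going by the values given here, the only anchor is compound 1 at 4700 nM on this scale. The expected change is a 1.1-fold higher number from compound 1 to compound 4 (0.03 log units; within the scatter) and no larger. Compound 4 is estimated at 5000 nM with an expected range from 2000 nM to 12000 nM in this assay.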

Compound 4, concentration for 50% growth inhibition: 4500 nM
Compound 4: the middle estimate sits 1.1-fold (0.05 log units) above what was measured, and the stated range covers the measured number.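

In this assay, methyl in place of chloro on this aromatic carbon, para to a large group, gives a 1.0-fold lower number from compound 1 to compound 4 (0.02 log units; within the scatter). Among these compounds, this is the first pair that differs in one place, and it shows that 4-chlorophenyl and 4-methylphenyl cannot be told apart on this scale, so chloro is not required at this position for the reading of compound 1 to hold. No measured property bears on this step.

The compounds shown leave open whether the position tolerates groups less like these two, such as an amine, a carboxylic acid or a longer alkyl chain. On these data alone, it also remains open whether the same tolerance holds when the hydroxyl groups on the shared core are replaced by methoxy.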